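The source may report more compounds than this note shows. Statements on the series, on what has been measured and on what is new or still open speak of the compounds shown alone.

Measured so far in a functional assay on KBVIN cells (Homo sapiens) for antiproliferative activity, read by sulforhodamine B assay, with a stated time of 3 days; a higher number here means that more compound is needed for the effect, a lower number that less compound is needed:
- compound 1 `CCCc1ccc(-c2cc(=O)c3c(o2)C(CC)(CC)C(=O)C(CC)=C3O)cc1`: 12.2 uM
- compound 2 `CCC1=C(O)c2c(oc(-c3ccc(COC)cc3)cc2=O)C(CC)(CC)C1=O`: 3.4 uM
- compound 3 `CCC1=C(O)c2c(oc(-c3ccc(C)cc3C)cc2=O)C(CC)(CC)C1=O`: 8.52 uM

These three share one core and differ only in the substituted phenyl group attached to it. Compound 3 cannot be told apart from compound 1, with a 1.4-fold lower number from compound 1 to compound 3 (0.16 log units; within the scatter). Compound 2 stands apart from both, with a 3.6-fold lower number from compound 1 to compound 2 (0.55 log units; beyond the scatter) and a 2.5-fold higher number from compound 2 to compound 3 (0.40 log units; beyond the scatter).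

Compound 4 `CCC1=C(O)c2c(oc(-c3ccc(OC)c(F)c3)cc2=O)C(CC)(CC)C1=O` keeps the core and has 3-fluoro-4-methoxyphenyl in place of 2,4-dimethylphenyl, on an aromatic carbon next to the ring oxygen: 3-fluoro-4-methoxyphenyl in place of 2,4-dimethylphenyl on an aromatic carbon.

Within the data shown here, no measured step makes this exact exchange, so the guidance is indirect. Swapping one phenyl group for another has so far given a 2.5-fold higher number from compound 2 to compound 3 (0.40 log units; beyond the scatter) and a 1.4-fold lower number from compound 1 to compound 3 (0.16 log units; within the scatter), so changes here have been modest or lost in the scatter. Among the measured compounds shown here, compound 2 is the only measured compound with oxygen in this group, and it gives 3.4 uM. This single example tilts the expectation slightly towards a lower number in this assay, but it is weak evidence.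

The expected change is small, a 1.4-fold lower number from compound 3 to compound 4 (0.15 log units; within the scatter). For compound 4 the estimated value is 6 uM, with an expected range from 2.5 uM to 14 uM.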

Compound 4, concentration for half-maximal effect: 0.1 uM
Compound 4: middle estimate off by 60-fold (1.78 log units), on the high side; the whole stated range lies above it.
By their numbers in this assay, from the lowest: compound 4; then compound 2; then compounds 3 and 1 (each within the scatter of the next).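

In this assay the group on the aromatic carbon next to the ring oxygen proves able to shift the number far more than the earlier exchanges suggested, since 3-fluoro-4-methoxyphenyl in place of 2,4-dimethylphenyl gives an 85-fold lower number from compound 3 to compound 4 (1.93 log units; beyond the scatter) in a single exchange. The same group also stands well apart from the other two phenyl groups, with a 34-fold lower number from compound 2 to compound 4 (1.53 log units; beyond the scatter) and a 120-fold lower number from compound 1 to compound 4 (2.09 log units; beyond the scatter) as the steps, so compound 4 has the lowest number of the four by a wide margin. Oxygen in this group is clearly not enough on its own, as compound 2 also carries an oxygen there and still needs much more compound than compound 4 does.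

Nothing available here accounts for the size of this step. Fluorine and methoxy enter together, so the compounds shown leave open which of the two carries the change, and whether 4-methoxyphenyl without the fluorine, 3-chloro-4-methoxyphenyl or a phenyl group bearing an amine would keep the number this low.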